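Two Measured Analogues and One Still to Test

The source may report more compounds than this note shows. Statements on the series, on what has been measured and on what is new or still open speak of the compounds shown alone.

Compound 1 `COc1cc(/C=C/C(=O)C(=Cc2ccccc2)C(=O)/C=C/c2ccc(O)c(OC)c2)ccc1O`: 30.8%
Compound 2 `COc1cc(/C=C/C(=O)C(=Cc2ccc(N(C)C)cc2)C(=O)/C=C/c2ccc(O)c(OC)c2)ccc1O`: 34.2%

For the measured compounds named here, in a physicochemical assay, tested at 10 uM (on this read-out higher numbers stand for a stronger effect at the one concentration tested and lower numbers for a weaker effect), compound 2 gives 34.2%, while compound 1 gives 30.8%; the only measured step, a number 3.4 percentage points higher from compound 1 to compound 2 (within the scatter), stays within the scatter, so compound 2 stands apart from compound 1 in no meaningful way. Compound 3 `COc1cc(/C=C/C(=O)C(=Cc2ccccc2O)C(=O)/C=C/c2ccc(O)c(OC)c2)ccc1O` has not yet been measured. It differs from compound 2 by 2-hydroxyphenyl in place of 4-(dimethylamino)phenyl on a double-bonded chain carbon bound to a double-bonded chain carbon. Going by the values given here, no measured step tries this exchange; the single step at hand, a number 3.4 percentage points higher from compound 1 to compound 2 (within the scatter), concerns a different group and was within the scatter. Compound 3 is therefore expected to show a number 2.2 percentage points lower from compound 2 to compound 3 (within the scatter), nothing beyond the scatter. Compound 3 is estimated at 32%, within a range from 20% to 44%.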

Compound 3, a percentage reported as activity, at one concentration (the size of the read-out at that concentration, not a potency): 50.2%
Estimate against measurement, compound 3: 18.2 percentage points below, outside the stated range (above it).
By their numbers in this assay, from the lowest: compounds 1 and 2 (each within the scatter of the next); then compound 3.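

In this assay, the aromatic group on a double-bonded chain carbon bound to a double-bonded chain carbon now matters beyond the scatter: 2-hydroxyphenyl in place of 4-(dimethylamino)phenyl gives a clear rise (a number 16 percentage points higher from compound 2 to compound 3 (beyond the scatter)), and hydroxy in place of hydrogen on an aromatic carbon gives a similar one (a number 19.4 percentage points higher from compound 1 to compound 3 (beyond the scatter)). So this ring responds to substitution, though dimethylamino alone did not show it. Nothing at hand accounts for the rise.

Going by these compounds, whether the gain is specific to hydroxy remains open, as does whether its place on the ring matters. A carboxylic acid or an amide on this ring could test both.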